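Phenyl in Place of (4-Chlorophenyl)amino: an Expectation

This account rests on a few compounds, and the source may have more. Where it says the series, first, only, none or still open, it means among the compounds named here.

Compound 1 `N#C/C(=C\N1CCN(C(=O)c2ccco2)C1=S)C(=O)Nc1ccc(Cl)cc1` carries a (4-chlorophenyl)amino group on a carbonyl carbon. In a functional assay on CCRF-CEM cells (Homo sapiens) for inhibition, read by sulforhodamine B assay, with a stated time of 48 h (a higher number here means a weaker inhibitor of growth, a lower number a stronger inhibitor of growth), compound 1 gives 22500 nM, the highest of the two numbers recorded. Compound 2 `COc1cc(C(=O)N2CCN(C=O)C2=S)cc(OC)c1OC` is its only companion; in this assay compound 2 gives 18300 nM, a number that sits within the scatter of compound 1, so neither can be called the weaker of the two. Among the measured compounds shown here, no step between measured compounds bears on the change at hand.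

Compound 3 `N#C/C(=C\N1CCN(C(=O)c2ccco2)C1=S)C(=O)c1ccccc1` differs from compound 1 in one place: phenyl in place of (4-chlorophenyl)amino on a carbonyl carbon. The amide hydrogen goes with the leaving group, and the chlorine too. For the measured compounds named here, with no measured pair to guide the direction, the author expects compound 3 to stay close to compound 1, a step of a 1.1-fold higher number from compound 1 to compound 3 (0.05 log units; within the scatter) that would not exceed the scatter. Compound 3 is therefore estimated at 25000 nM in this assay, with a range from 8000 nM to 80000 nM.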

Compound 3, concentration for 50% growth inhibition: 41900 nM
The estimate for compound 3 lay 1.7-fold (0.22 log units) below the measured number; the measured number falls inside the stated range.
By their numbers in this assay, from the lowest: compounds 2, 1 and 3 (each within the scatter of the next, the first and the last beyond it).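

In this assay, among the compounds shown here, phenyl in place of (4-chlorophenyl)amino on a carbonyl carbon gives a 1.9-fold higher number from compound 1 to compound 3 (0.27 log units; within the scatter), the first measured step at this position. The amide hydrogen and the chlorine leave together in this step, yet compound 1 and compound 3 cannot be told apart, so this exchange of groups yields no clear gain or loss in growth inhibition. Nothing measured here explains the result.

The step cannot show what the amide hydrogen and the chlorine each contribute on their own, since both go at once; phenylamino or 4-chlorophenyl on the same carbonyl carbon would separate the two. Going by these compounds, it also remains open whether a group of another kind there, such as a morpholine or a carboxylic acid, would shift the number beyond the scatter.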